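Chain extension in a benzenesulfonamide series: lipophilicity notes

A few compounds are considered here, and "the series" means these few. Any claim that something is new, unique, unknown or untested is made for them only; others in the source may bear on it.

Measured so far:
compound 1, `CCNC(=O)c1ccc(S(N)(=O)=O)cc1`: 0.03
compound 2, `CCCNC(=O)c1ccc(S(N)(=O)=O)cc1`: 0.51
compound 3, `CCCOC(=O)c1cccc(S(N)(=O)=O)c1`: 1.72

All three numbers come from a physicochemical assay for lipophilicity; on this read-out lower numbers stand for lower lipophilicity and higher numbers for higher lipophilicity. Compound 1 gives 0.03 and compound 2 gives 0.51 in this assay; the pair differs by methyl in place of hydrogen on a saturated chain carbon, two bonds along the chain from an amide-type nitrogen and the step is a number 0.48 log units higher from compound 1 to compound 2 (beyond the scatter). Compound 3 sits highest of the three in this assay with 1.72. How the core of compound 3 differs from the core of compound 1 is not broken down here; the two differ in more than one place.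

Compound 4, `CCCCOC(=O)c1cccc(S(N)(=O)=O)c1`, remains to be measured in this assay. It differs from compound 3 by methyl in place of hydrogen on a saturated chain carbon, three bonds along the chain from an oxygen next to a carbonyl group. This is the same kind of change as that from compound 1 to compound 2, though not the same: there the added carbon sat two bonds along the chain from an amide-type nitrogen, here it sits three bonds along the chain from an oxygen next to a carbonyl group. Going by the values given here, only one such step is available as a guide.

The step from compound 3 to compound 4 is estimated as a number 0.48 log units higher from compound 3 to compound 4 (beyond the scatter) because the same kind of change gave a number 0.48 log units higher from compound 1 to compound 2 (beyond the scatter). Compound 4 is expected to give 2.2 in this assay, with an estimated range from 1.9 to 2.5.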

Compound 4, partition coefficient: 2.24
Compound 4: the middle estimate sits 0.04 log units below what was measured; low and high end bracket the measured number.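

In this assay, the added methyl gives a number 0.52 log units higher from compound 3 to compound 4 (beyond the scatter), and the same kind of change on the other core gives a number 0.48 log units higher from compound 1 to compound 2 (beyond the scatter); both steps run the same way and each lies beyond the scatter. This supports carrying the change between these two cores only, where the added carbon sits two bonds along the chain from an amide-type nitrogen in one case and three bonds along the chain from an oxygen next to a carbonyl group in the other, and two steps set no general rule for other cores or other places on a chain. Nothing at hand gives a reason for the size of either step.

The compounds shown leave open what a chain longer than butyl would give on the core of compound 3, and whether the step would keep its size there. They also leave open how a chain ending in an amine or a carboxylic acid would read in this assay.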